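This account rests on a few compounds, and the source may have more. Where it says the series, first, only, none or still open, it means among the compounds named here.

Compound 1 `Cc1nc2cnccc2n1CC1CCN(C(=O)CCc2ccccc2)CC1` gives 60 nM
Compound 2 `Cc1nc2cnccc2n1CC1CCN(C(=O)N[C@H](C)c2ccccc2)CC1` gives 13 nM

In a functional assay (plasma) with Oryctolagus cuniculus as the target (a lower number here means a stronger inhibitor, a higher number a weaker inhibitor), compound 2 (13 nM) holds the lower of the two numbers. Compound 3 `Cc1nc2cnccc2n1CC1CCN(C(=O)NC2(c3ccccc3)CC2)CC1` carries 1-phenylcyclopropyl in place of 1-phenylethyl on an amide-type nitrogen and has not yet been measured. Going by the values given here, the only measured step (a 4.6-fold lower number from compound 1 to compound 2 (0.66 log units; beyond the scatter)) is a different change, so it gives no direct guide to this one. No step beyond the scatter is therefore expected in this assay and the estimated step (a 1.2-fold higher number from compound 2 to compound 3 (0.06 log units; within the scatter)) is small. Compound 3 is estimated at 15 nM (range 5 nM to 45 nM) in this measurement.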

Compound 3, half-maximal inhibitory concentration: 17 nM
Estimate against measurement, compound 3: 1.1-fold (0.05 log units) below; the range from low to high includes it.
By their numbers in this assay, from the lowest: compounds 2 and 3 (each within the scatter of the next); then compound 1.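

In this assay the amide-type nitrogen accepts 1-phenylcyclopropyl in place of 1-phenylethyl (a 1.3-fold higher number from compound 2 to compound 3 (0.12 log units; within the scatter)). The three-membered ring enters and the defined stereocentre leaves, yet the number stays within the scatter, so at this position neither that ring nor that stereocentre shows a measurable effect on the number. Nothing available here accounts for this result.

The compounds shown leave open how a larger ring such as 1-phenylcyclobutyl would fare at this position. They also leave open what an amine or a methoxy group on the phenyl ring would do.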